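This account rests on a few compounds, and the source may have more. Where it says the series, first, only, none or still open, it means among the compounds named here.

Compound 1 `CS/C(=N\C(=O)c1ccno1)NC(=O)c1ccno1` is one of three measured compounds in a functional assay on MCF7 cells (Homo sapiens) for cytotoxicity, read by MTT assay, with a stated time of 72 h; a higher number here means a weaker inhibitor of growth, a lower number a stronger inhibitor of growth. In this assay compound 1 gives only a limit, > 100000 nM. The limit line the limit of > 100000 nM in this assay, at which 2 of the 3 values shown sit, is where compound 1 stands, and compound 3 `CS/C(=N\C(=O)c1cnc2ccccc2c1)NC(=O)c1cnc2ccccc2c1` sits at the same limit, > 100000 nM. Compound 2 `CS/C(=N\C(=O)c1cc(-c2ccccc2)nc2ccccc12)NC(=O)c1cc(-c2ccccc2)nc2ccccc12` gives 87700 nM in this assay. Compound 4 `C[Se]/C(=N\C(=O)c1ccno1)NC(=O)c1ccno1` differs from compound 1 in one place: a group of 2 heavy atoms (1 carbon, 1 selenium; no ring) in place of a group of 2 heavy atoms (1 carbon, 1 sulfur; no ring), on a carbon with a double bond to nitrogen. No step between measured compounds is shown, so the size of this change is unknown. Compound 4 is expected to stay near compound 1, within the usual scatter, with a step of a number no higher from compound 1 to compound 4 (the limit leaves the size open), and most likely to return a limit again. Compound 4 is therefore estimated at 100000 nM in this assay, within 30000 nM to 300000 nM.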

Compound 4, concentration for total growth inhibition: 57500 nM
Beside the measured number, compound 4's estimate is 1.7-fold (0.24 log units) above it, and the stated range covers the measured number.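

In this assay, putting the group of one carbon and one selenium in place of methylsulfanyl, on the carbon with a double bond to nitrogen, gives the first step read at this position: an at least 1.7-fold lower number from compound 1 to compound 4 (0.24 log units; that floor lies within the scatter). This floor alone does not establish a real change, although the true step may be larger. Its size stays open because compound 1 gives only a limit: the limit of > 100000 nM in this assay, at which 2 of the 4 values shown sit.

The compounds shown leave open whether the same exchange would shift the number for compound 2 or compound 3. They also leave open how a methoxy group or an amine would behave on this carbon.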